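Swapping 4-chlorophenyl for 3-methoxyphenyl on the shared core

This account rests on a few compounds, and the source may have more. Where it says the series, first, only, none or still open, it means among the compounds named here.

- compound 1 `COc1cccc(/C=C2\CCC/C(=C\c3ccc(Cl)cc3)C2=O)c1OC`: > 20000 nM
- compound 2 `COc1cccc(/C=C2\CCC/C(=C\c3cccc(Br)c3)C2=O)c1OC`: > 20000 nM

In a functional assay on A549 cells (Homo sapiens) for cytotoxicity, read by MTT assay, with a stated time of 72 h (a lower number here means a stronger inhibitor, a higher number a weaker inhibitor), compound 1 gives > 20000 nM, which is a limit and not a number. Compound 2 gives > 20000 nM in this assay, which is also a limit. Among the compounds with values here, the series so far therefore rests on (the limit of > 20000 nM in this assay, at which 2 of the 2 values shown sit).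

Compound 3 `COc1cccc(/C=C2\CCC/C(=C\c3cccc(OC)c3OC)C2=O)c1` has not yet been measured. Its difference from compound 1 is 3-methoxyphenyl in place of 4-chlorophenyl on a double-bonded chain carbon bound to a double-bonded ring carbon: 3-methoxyphenyl in place of 4-chlorophenyl, on a double-bonded chain carbon bound to a double-bonded ring carbon.

Within the data shown here, only one measured step bears on this change, also a replacement of the 4-chlorophenyl group. It is a step that the two limits leave unreadable from compound 1 to compound 2, so it offers no size to carry over. Among the measured compounds shown here, with > 20000 nM for compound 1 as the starting point, no step of readable size and no direction can be expected in this assay, and another reported limit is the likeliest outcome. The expected step is a number no higher from compound 1 to compound 3 (the limit leaves the size open). Compound 3 is estimated at 20000 nM, with an expected range of 8000 nM to 40000 nM.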

Compound 3, half-maximal inhibitory concentration: 16400 nM
Compound 3: middle estimate off by 1.2-fold (0.09 log units), on the high side, and the stated range covers the measured number.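

In this assay, within the data shown here, compound 3 gives 16400 nM, the first actual number rather than a limit, so the change on a double-bonded chain carbon bound to a double-bonded ring carbon now has one readable end point on the shared core. The replacement of 4-chlorophenyl by 3-methoxyphenyl gives an at least 1.2-fold lower number from compound 1 to compound 3 (0.08 log units; that floor lies within the scatter), and methoxy in place of bromo on an aromatic carbon gives an at least 1.2-fold lower number from compound 2 to compound 3 (0.08 log units; that floor lies within the scatter), so neither comparison establishes a real gain for the methoxy-bearing ring. Both steps remain floors rather than sizes, because the values they start from are limits: the limit of > 20000 nM in this assay, at which 2 of the 3 values shown sit.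

How large the true gaps are remains open, since the values on the halogen-bearing side are not numbers, and the compounds shown do not separate the effect of the methoxy group from that of removing a halogen. Also open, going by these compounds, is how a phenyl ring carrying an amine or a carboxylic acid would read in this assay at this same place on the shared core.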